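This account rests on a few compounds, and the source may have more. Where it says the series, first, only, none or still open, it means among the compounds named here.

Measured compounds in a functional assay on the whole organism for activation, with Mus musculus as the target; a lower number here means that less compound is needed, a higher number that more compound is needed for the effect:

- Compound 1, `CCCNc1nc(N)c2nc(O)n(Cc3ccccc3)c2n1`, gives 1 mg/kg.
- Compound 2, `Cc1nc(N)c2nc(O)n(Cc3ccccc3)c2n1`, gives 3 mg/kg.
- Compound 3, `CCCC[S+]([O-])c1nc(N)c2nc(O)n(Cc3ccccc3)c2n1`, gives 1 mg/kg.

Compound 3 stands level with compound 1 at the digits reported, and the two share the lowest number of the three. The one clear gap is the step of a 3.0-fold lower number from compound 2 to compound 3 (0.48 log units; beyond the scatter), which lies beyond the scatter; the step of no change at the digits printed from compound 1 to compound 3 (within the scatter) does not.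

Compound 4, `CCCCNc1nc(N)c2nc(O)n(Cc3ccccc3)c2n1`, differs from compound 3 in one place: a group of 5 heavy atoms (4 carbon, 1 nitrogen; no ring) in place of a group of 6 heavy atoms (4 carbon, 1 oxygen, 1 sulfur; no ring), on an aromatic carbon. Butylamino is a close relative of the propylamino in compound 1, so the step of no change at the digits printed from compound 1 to compound 3 (within the scatter) bears most directly on it: swapping propylamino for the six-atom group left the number unchanged, so an alkylamino group and this group appear interchangeable here. The step of a 3.0-fold higher number from compound 1 to compound 2 (0.48 log units; beyond the scatter) shows that only the shrink to methyl cost anything. Going back from the six-atom group to an alkylamino group, compound 4 is therefore expected to show no change beyond the scatter, no change at the digits printed from compound 3 to compound 4 (within the scatter). The estimate for compound 4 is 1 mg/kg, with a range from 0.5 mg/kg to 3 mg/kg.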

Compound 4, minimum effective dose: 0.1 mg/kg
Compound 4: the middle estimate sits 10-fold (1.00 log units) above what was measured; measured number outside the range, below it.
By their numbers in this assay, from the lowest: compound 4; then compounds 1 and 3 (each within the scatter of the next); then compound 2.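

In this assay, this position proves sensitive to the exact length of the alkylamino chain: butylamino in place of methyl gives a 30-fold lower number from compound 2 to compound 4 (1.48 log units; beyond the scatter) and is the widest step in this set, while a single methyl added at the end of the propylamino chain already gives a 10-fold lower number from compound 1 to compound 4 (1.00 log units; beyond the scatter) on its own. The earlier match between propylamino and the sulfur-and-oxygen group therefore did not mean that the position treats such groups alike, since butylamino in place of that group gives a 10-fold lower number from compound 3 to compound 4 (1.00 log units; beyond the scatter) even though both groups hold four carbons. Nothing measured here accounts for these steps, so the numbers show how much the change matters but not the reason for it.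

Going by these compounds, it remains open whether a longer chain, such as pentylamino or hexylamino, would lower the number further or raise it again, so the best chain length at this position is unsettled. It is equally unclear how much depends on the linking nitrogen, which butoxy, with an oxygen in its place, or a branched amine such as isobutylamino could help to test.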